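The compounds below may be only part of what the source reports. "The series", "measured", "known", "first", "only" and "open" are said of these compounds alone.

Among the measured compounds shown here, in a functional assay on KB cells (Homo sapiens) for cytotoxicity, read by MTT assay, with a stated time of 3 days (on this read-out lower numbers stand for stronger inhibition and higher numbers for weaker inhibition), three compounds sharing one core have numbers so far. Compound 1 `N#Cc1c(Nc2ccccc2)nc(SCc2nc3ccccc3[nH]2)nc1-c1ccccc1` gives 2.9 nM, compound 2 `CNc1nc(SCc2nc3ccccc3[nH]2)nc(-c2ccccc2)c1C#N` gives 2.7 nM, and compound 3 `N#Cc1c(Nc2ccccn2)nc(SCc2nc3ccccc3[nH]2)nc1-c1ccccc1` gives 7.35 nM. Compound 3 therefore has the highest number of the three, which marks it as the least potent in this small set.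

Compound 4 `N#Cc1c(Nc2nccs2)nc(SCc2nc3ccccc3[nH]2)nc1-c1ccccc1` has not yet been measured. It differs from compound 3 in a single place, with 1,3-thiazol-2-yl in place of pyridin-2-yl on a nitrogen on an aromatic ring. All three measured steps concern this same place. Exchanging phenyl for methyl gives a 1.1-fold lower number from compound 1 to compound 2 (0.03 log units; within the scatter), which is within the scatter. Exchanging phenyl for pyridin-2-yl gives a 2.5-fold higher number from compound 1 to compound 3 (0.40 log units; beyond the scatter), and exchanging methyl for pyridin-2-yl gives a 2.7-fold higher number from compound 2 to compound 3 (0.43 log units; beyond the scatter), both of them modest. For the measured compounds named here, no measured compound carries 1,3-thiazol-2-yl, so this evidence is only indirect. Still, the changes at this place have stayed small so far, so at most a modest step is expected in this assay, with a slight lean towards a lower number. The expected step is a 1.3-fold lower number from compound 3 to compound 4 (0.13 log units; within the scatter). Compound 4 is estimated at 5.5 nM, with an expected range from 2.2 nM to 14 nM.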

Compound 4, half-maximal inhibitory concentration: 14.7 nM
The estimate for compound 4 lay 2.7-fold (0.43 log units) below the measured number; measured number above the stated range.
By their numbers in this assay, from the lowest: compounds 2 and 1 (each within the scatter of the next); then compounds 3 and 4 (each within the scatter of the next).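

In this assay, the place on the nitrogen on an aromatic ring now holds a second group that moves the number clearly away from phenyl, with a 5.1-fold higher number from compound 1 to compound 4 (0.70 log units; beyond the scatter), and from methyl, with a 5.4-fold higher number from compound 2 to compound 4 (0.74 log units; beyond the scatter). Against pyridin-2-yl, the swap to 1,3-thiazol-2-yl gives a 2.0-fold higher number from compound 3 to compound 4 (0.30 log units; within the scatter), so a five-membered aromatic ring with two hetero atoms cannot be told apart from the six-membered ring with one, and the four compounds fall into two pairs: compounds 1 and 2 on the low side, compounds 3 and 4 on the high side, with the phenyl ring of compound 1 sitting alongside the methyl of compound 2 and not alongside the other two aromatic rings. Nothing available accounts for this split between the pairs.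

The compounds shown leave open whether the split follows the hetero atoms in the ring or something else about these groups, which a benzyl or cyclohexyl group on this nitrogen, or a longer chain such as butyl in place of methyl, would help to separate. They also leave open whether the same two pairs would appear with a different group on the shared core, for instance an amine or a carboxylic acid on the phenyl ring of the anilino nitrogen.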